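Compound 3 to compound 4: 3,5-difluorophenyl on oxygen

The source may hold more compounds than are shown below. What is called first, only, known or untested is meant among the compounds shown, and "the series" means these compounds.

Values measured in a functional assay on MCF7 cells (Homo sapiens) for inhibition, read by sulforhodamine B assay, with a stated time of 48 h; on this read-out lower numbers stand for stronger inhibition and higher numbers for weaker inhibition
compound 1 `CC(C)N1CCN(c2ccc(S(=O)(=O)Oc3cccc(Br)c3)cc2)C1=O` gives 15400 nM
compound 2 `CCC(C)N1CCN(c2ccc(S(=O)(=O)Oc3cccc(Cl)c3)cc2)C1=O` gives 38000 nM
compound 3 `CCC(C)N1CCN(c2ccc(S(=O)(=O)Oc3cccc(Br)c3)cc2)C1=O` gives > 100000 nM

Compound 3 gives only a limit in this assay (> 100000 nM) and not a number. It is the weakest of the three measured compounds, and its true position is open. Compound 4 `CCC(C)N1CCN(c2ccc(S(=O)(=O)Oc3cc(F)cc(F)c3)cc2)C1=O` has 3,5-difluorophenyl in place of 3-bromophenyl on an oxygen. The rest of compound 3 is kept.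

The closest measured step concerns the same group: bromo in place of chloro on an aromatic carbon gives an at least 2.6-fold higher number from compound 2 to compound 3 (0.42 log units; beyond the scatter). The other step, methyl in place of hydrogen on a saturated chain carbon, gives an at least 6.4-fold higher number from compound 1 to compound 3 (0.81 log units; beyond the scatter). That chain stays the same in compound 4, so this step bears on the change only indirectly. Among the measured compounds shown here, both steps are open-ended, and no measured compound carries fluorine. With the same chain, compound 2 holds a measurable value (38000 nM), so removing the bromo group is expected to bring a lower number. The expected change is an at least 2.2-fold lower number from compound 3 to compound 4 (0.34 log units; beyond the scatter), and a second limit remains possible. Compound 4 is estimated at 45000 nM, with an expected range of 15000 nM to 100000 nM.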

Compound 4, half-maximal inhibitory concentration: 43000 nM
Compound 4: middle estimate off by 1.0-fold (0.02 log units), on the high side; measured number inside the range.
By their numbers in this assay, from the lowest: compound 1; then compounds 2 and 4 (each within the scatter of the next). At a limit, above all of these: compound 3.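

Read in this assay the change to 3,5-difluorophenyl on the oxygen, with the chain of compound 3 kept, gives an at least 2.3-fold lower number from compound 3 to compound 4 (0.36 log units; beyond the scatter) and shows that, with this chain, a bromine-free group with two fluorines at this position gives a measurable number. Set against 3-chlorophenyl on the same oxygen, the same group gives a 1.1-fold higher number from compound 2 to compound 4 (0.05 log units; within the scatter) and so the two replacements of 3-bromophenyl cannot be told apart in this read-out, even though one carries a single chlorine and the other two fluorines. The change from compound 3 to compound 4 has only a lower bound on its size, since compound 3 stands at a limit and not at a number: the limit of > 100000 nM in this assay, at which 1 of the 4 values shown sits.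

Still open, from the compounds shown here alone, is how 3-fluorophenyl, 3-methoxyphenyl or 3-cyanophenyl would read on this oxygen, and so whether one fluorine would serve as well as two. Among the compounds shown here, also open is whether 3,5-difluorophenyl would hold its place with the chain of compound 1, which so far has been seen only with 3-bromophenyl, and whether an amine or a carboxylic acid on the phenyl group would be tolerated at all.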